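Aryl ester series on the shared core: compound 3

The compounds below may be only part of what the source reports. "The series", "measured", "known", "first", "only" and "open" are said of these compounds alone.

Measured so far:
compound 1 `CC1=CC[C@H](C(C)C)c2cc(C)c(OC(=O)c3ccc(C)cc3)cc21` — 78.9%
compound 2 `CC1=CC[C@H](C(C)C)c2cc(C)c(OC(=O)c3ccc(Cl)cc3)cc21` — 47.4%

In a functional assay on HCT-15 cells (Homo sapiens) for antiproliferative activity, read by sulforhodamine B assay, with a stated time of 48 h, tested at 50 uM (on this read-out higher numbers stand for more inhibition at the one concentration tested (going by the name of the read-out) and lower numbers for less inhibition), compound 1 gives 78.9% and compound 2 gives 47.4%. Among the compounds with values here, the one step measured so far is a number 31.5 percentage points lower from compound 1 to compound 2 (beyond the scatter), the change being chloro in place of methyl on an aromatic carbon. Within the data shown here, compound 2 thus stands lowest of the two numbers, with compound 1 the only neighbour and beyond the scatter above it.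

Compound 3 `CC1=CC[C@H](C(C)C)c2cc(C)c(OC(=O)c3cccc(Cl)c3)cc21` is not yet measured. It differs from compound 2 by 3-chlorophenyl in place of 4-chlorophenyl on a carbonyl carbon. Among the measured compounds shown here, no measured step bears directly on this: the step from compound 1 to compound 2 swaps one group for another, whereas here the same atoms are joined differently. With nothing to indicate a direction, the step of a number 0.4 percentage points lower from compound 2 to compound 3 (within the scatter) is expected to lie within the scatter. Compound 3 is therefore estimated at 47%, with a range from 25% to 70%.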

Compound 3, a percentage reported as inhibition, at one concentration (the size of the read-out at that concentration, not a potency): 5.3%
For compound 3 the middle estimate is 41.7 percentage points above the measured one; measured number outside the range, below it.
By their numbers in this assay, from the lowest: compound 3; then compound 2; then compound 1.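

Notes on the aryl ester: in this assay the same chlorine atom gives very different numbers depending on how it is joined, with a number 42.1 percentage points lower from compound 2 to compound 3 (beyond the scatter). Within the data shown here, the earlier compounds showed only that the group on the ring matters; this step shows that, with the atoms unchanged, the arrangement of the ring alone is enough for a large change. Against the 4-methylphenyl ester, the 3-chlorophenyl ester gives a number 73.6 percentage points lower from compound 1 to compound 3 (beyond the scatter), the widest gap among these three compounds, and no measurement at hand explains the drop.

Whether the arrangement matters as much for groups other than chloro stays open, as the compounds shown hold no ester with an amine or a carboxylic acid on this ring. All numbers come from a single concentration, so they leave potency open.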